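The compounds below may be only part of what the source reports. "The series", "measured", "known", "first", "only" and "open" are said of these compounds alone.

Measured in an assay on isolated protein for inhibition of Rho-associated protein kinase 2 (Homo sapiens), read by scintillation counting, radiometric assay and 33P incorporation, with a stated time of 40 min, in the presence of a further agent that is not named here; a lower number here means a stronger inhibitor, a higher number a weaker inhibitor:

compound 1 `CC(=O)Nc1cccc(NC(=O)COc2ccc3c(=O)ccoc3c2)c1`: 136 nM
compound 2 `O=C(COc1ccc2c(=O)ccoc2c1)Nc1cccc(NC(=O)c2ccc(F)cc2)c1`: 54 nM
compound 3 `O=C(COc1ccc2c(=O)ccoc2c1)Nc1cccc(NC(=O)c2cnc(C(F)(F)F)s2)c1`: 10 nM

Compound 1 gives the highest number of the three in this assay. Its nearest neighbour is compound 2, reached by a 2.5-fold lower number from compound 1 to compound 2 (0.40 log units; beyond the scatter); the furthest is compound 3, reached by a 14-fold lower number from compound 1 to compound 3 (1.13 log units; beyond the scatter). Between the two aryl amides the step is a 5.4-fold lower number from compound 2 to compound 3 (0.73 log units; beyond the scatter).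

Compound 4 `NCc1ccc(C(=O)Nc2cccc(NC(=O)COc3ccc4c(=O)ccoc4c3)c2)cc1` has not yet been measured in this assay. Against compound 1 the change is 4-(aminomethyl)phenyl in place of methyl on a carbonyl carbon.

Both measured steps from compound 1 replace the same methyl on the carbonyl carbon by an aromatic group, and both lower the number beyond the scatter: modestly in a 2.5-fold lower number from compound 1 to compound 2 (0.40 log units; beyond the scatter), strongly in a 14-fold lower number from compound 1 to compound 3 (1.13 log units; beyond the scatter). The change to compound 4 is of the same kind, a six-membered aromatic ring entering at the same place. A lower number than compound 1 is therefore expected in this assay, most likely of a size nearer to the step to compound 2, since the entering group is a phenyl ring like that of compound 2 rather than the group of compound 3. For compound 4 the expected step is a 2.7-fold lower number from compound 1 to compound 4 (0.43 log units; beyond the scatter). Compound 4 is estimated at 50 nM, with a range from 20 nM to 130 nM.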

Compound 4, half-maximal inhibitory concentration: 66 nM
Beside the measured number, compound 4's estimate is 1.3-fold (0.12 log units) below it, and the stated range covers the measured number.
By their numbers in this assay, from the lowest: compound 3; then compounds 2 and 4 (each within the scatter of the next); then compound 1.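

In this assay, the 4-(aminomethyl)phenyl group also lowers the number, with a 2.1-fold lower number from compound 1 to compound 4 (0.31 log units; beyond the scatter), so the gain over methyl on this carbonyl carbon is not confined to the fluorinated aromatic groups. Aminomethyl in place of fluoro on the aromatic carbon gives a 1.2-fold higher number from compound 2 to compound 4 (0.09 log units; within the scatter), so this assay does not separate these two phenyl groups. The 2-(trifluoromethyl)-1,3-thiazol-5-yl group remains apart from both, with a 6.6-fold higher number from compound 3 to compound 4 (0.82 log units; beyond the scatter). No measurement at hand accounts for these differences.

From the compounds shown here alone, whether the advantage of compound 3 belongs to the thiazole ring or to its trifluoromethyl group stays open, and a phenyl ring bearing trifluoromethyl at this place would separate the two. Also open, going by these compounds, is how a carboxylic acid or a longer aminoalkyl chain in place of aminomethyl would read.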